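Cytotoxicity notes: propanoyl amide of the aniline

A few compounds are considered here, and "the series" means these few. Any claim that something is new, unique, unknown or untested is made for them only; others in the source may bear on it.

Compound 3 `Cn1c(-c2ccc(N)cc2)nc2cc(C(F)(F)F)ccc21` is the free aniline of the series. In an ADME assay on Vero cells (Chlorocebus sabaeus) for cytotoxicity (on this read-out higher numbers stand for lower toxicity in this test and lower numbers for higher toxicity in this test), compound 3 gives > 100000 nM, which is a limit of the assay and not a number. Compound 1 `Cn1c(-c2ccc(NC(=O)CN3CCCCC3)cc2)nc2cc(C(F)(F)F)ccc21` carries the ((piperidin-1-yl)methyl)carbonyl on the same nitrogen; in this assay compound 1 gives > 100000 nM, again a limit. Going by the values given here, compound 2 `Cn1c(-c2ccc(NC(=O)CN3CCN(c4ccccc4)CC3)cc2)nc2cc(C(F)(F)F)ccc21` is the one member with a number: in this assay compound 2 gives 30000 nM. Among the compounds with values here, the step of an at least 3.3-fold lower number from compound 1 to compound 2 (0.52 log units; beyond the scatter) is the only readable change, while the step that the two limits leave unreadable from compound 1 to compound 3 cannot be sized because both ends sit at the limit of > 100000 nM in this assay, at which 2 of the 3 values shown sit.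

Compound 4 `CCC(=O)Nc1ccc(-c2nc3cc(C(F)(F)F)ccc3n2C)cc1` is not yet measured. Relative to compound 3 the change is propanoyl in place of hydrogen on a nitrogen on an aromatic ring. Neither measured step maps directly onto it: the step that the two limits leave unreadable from compound 1 to compound 3 covers acylation of this nitrogen but stays unreadable, and the step of an at least 3.3-fold lower number from compound 1 to compound 2 (0.52 log units; beyond the scatter) concerns the amine on the chain, which compound 4 lacks. Since compound 1 with its larger acyl group remains at the limit, no step beyond the scatter is expected, and the estimated step of a number no higher from compound 3 to compound 4 (the limit leaves the size open) reflects that. Compound 4 is expected to give 100000 nM, within 50000 nM to 200000 nM, most likely reported as a limit again.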

Compound 4, half-maximal cytotoxic concentration: > 100000 nM
Compound 4 gave a limit, no number (the forecaster's own chance of this, stated with the estimate: 75%); the middle value lies on the limit itself.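

In this assay compound 4 gives > 100000 nM, a limit of the assay and not a number, so a small open-chain propanoyl on this aromatic nitrogen, with no amine on the chain, also yields no number. With methyl in place of 4-phenylpiperazin-1-yl on the chain carbon, the read-out shows an at least 3.3-fold higher number from compound 2 to compound 4 (0.52 log units; beyond the scatter), and among the compounds shown the only number stays with the compound carrying 4-phenylpiperazin-1-yl. The steps to compound 4 from compound 3 and from compound 1 cannot be read, as both ends of each are limits: the limit of > 100000 nM in this assay, at which 3 of the 4 values shown sit.

From the compounds shown here alone, whether acylation of this nitrogen moves the read-out at all remains open. Also open, going by these compounds, is whether that number follows the phenyl or the piperazine: an unsubstituted piperazine or a morpholine on the same chain carbon would separate the two.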